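Ring Size on the Amine Chain: Compound 3 to Compound 4

The source may hold more compounds than are shown below. What is called first, only, known or untested is meant among the compounds shown, and "the series" means these compounds.

Compound 1 `COc1cc2c(Oc3ccc(NC(=O)c4cc(-c5ccccc5F)ccn4)cc3F)ccnc2cc1OCCCN1CCCCC1` gives 320 nM in a functional assay on HT-29 cells (Homo sapiens) for cytotoxicity, read by MTT assay, with a stated time of 72 h; a lower number here means a stronger inhibitor, a higher number a weaker inhibitor.
Compound 2 `COc1ccc(-c2ccnc(C(=O)Nc3ccc(Oc4ccnc5cc(OCCCN6CCCCC6)c(OC)cc45)c(F)c3)c2)cc1` gives 690 nM.
Compound 3 `COc1cc2c(Oc3ccc(NC(=O)c4cc(-c5ccc(C)cc5)ccn4)cc3F)ccnc2cc1OCCCN1CCCC1` gives 350 nM.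

Compound 3 stands second highest of the three numbers; its gap to compound 1 and its gap to compound 2 both fall inside the usual scatter, so no ranking among them is secure. Compound 4 `COc1cc2c(Oc3ccc(NC(=O)c4cc(-c5ccc(C)cc5)ccn4)cc3F)ccnc2cc1OCCCN1CCCCC1` differs from compound 3 by piperidin-1-yl in place of pyrrolidin-1-yl on a saturated chain carbon, three bonds along the chain from an oxygen on an aromatic ring. Going by the values given here, the only measured step, a 2.2-fold higher number from compound 1 to compound 2 (0.33 log units; beyond the scatter), concerns a different aromatic group and says nothing about the amine ring. Compounds 1 and 2 already carry the piperidin-1-yl group and give numbers in the same region as compound 3. The expected step of no change at the digits printed from compound 3 to compound 4 (within the scatter) is therefore none beyond the scatter. Compound 4 is estimated at 350 nM, with a range from 170 nM to 700 nM.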

Compound 4, half-maximal inhibitory concentration: 340 nM
Compound 4: the middle estimate sits 1.0-fold (0.01 log units) above what was measured; measured number inside the range.
By their numbers in this assay, from the lowest: compounds 1, 4, 3 and 2 (each within the scatter of the next, the first and the last beyond it).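

Changing 3-(pyrrolidin-1-yl)propyl to 3-(piperidin-1-yl)propyl gives a 1.0-fold lower number from compound 3 to compound 4 (0.01 log units; within the scatter) in this assay and so leaves the reading unchanged within the scatter at this position. With piperidin-1-yl held fixed, methyl in place of methoxy gives a 2.0-fold lower number from compound 2 to compound 4 (0.31 log units; beyond the scatter) while 4-methylphenyl in place of 2-fluorophenyl gives a 1.1-fold higher number from compound 1 to compound 4 (0.03 log units; within the scatter) and only the first of these lies beyond the scatter. No measurement here offers an explanation for these steps.

On these data alone, whether a morpholin-4-yl ring or an open-chain dimethylamino group on the same chain would read alike stays open, as does the effect of a longer chain.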